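Squalene synthase series: phenyl for propanoyloxy on compound 3

This account rests on a few compounds, and the source may have more. Where it says the series, first, only, none or still open, it means among the compounds named here.

Measured compounds:
- compound 1 `C=CCc1ccccc1OCCCNC(C)C`, 56 nM
- compound 2 `CC(C)NCCCOc1ccc(-c2ccccc2)cc1`, 170 nM
- compound 3 `C=CCc1cc(OC(=O)CC)ccc1OCCCNC(C)C`, 0.05 nM

In an assay for inhibition of squalene synthase (Rattus norvegicus), using microsomes (on this read-out lower numbers stand for stronger inhibition and higher numbers for weaker inhibition), compound 3 gives the lowest number of the three; compound 1 stands nearest, compound 2 furthest, both beyond the scatter. Compound 4 `C=CCc1cc(-c2ccccc2)ccc1OCCCNC(C)C` is obtained from compound 3 by the change (phenyl in place of propanoyloxy on an aromatic carbon).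

Within the data shown here, the only measured step at this position is a 1100-fold lower number from compound 1 to compound 3 (3.05 log units; beyond the scatter), a large one, but it concerns propanoyloxy entering for hydrogen, not phenyl. Compound 2 carries a phenyl at the position para to the ether chain and lacks the allyl group; in this assay compound 2 gives 170 nM while compound 1 gives 56 nM, which is all that can be said of a phenyl at that place. Among the measured compounds shown here, no step shows whether phenyl reproduces the gain that propanoyloxy brought. The expectation for compound 4 is therefore a number well above that of compound 3, a step of a 400-fold higher number from compound 3 to compound 4 (2.60 log units; beyond the scatter), landing nearer compound 1 than compound 3, with wide uncertainty. Compound 4 is estimated at 20 nM, within 2 nM to 200 nM.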

Compound 4, half-maximal inhibitory concentration: 0.004 nM
Compound 4: middle estimate off by 5000-fold (3.70 log units), on the high side; measured number below the stated range.
By their numbers in this assay, from the lowest: compound 4; then compound 3; then compound 1; then compound 2.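

In this assay phenyl on this aromatic carbon does more than stand in for propanoyloxy, with a 13-fold lower number from compound 3 to compound 4 (1.10 log units; beyond the scatter), so a ring of carbon only, with no hydrogen-bond acceptors, serves here better than the ester group. Against hydrogen the same phenyl gives a 14000-fold lower number from compound 1 to compound 4 (4.15 log units; beyond the scatter), and with phenyl in place, allyl for hydrogen gives a 43000-fold lower number from compound 2 to compound 4 (4.63 log units; beyond the scatter), a step that shows the allyl group counts heavily in this pairing. Nothing measured here offers a reason for these steps.

Open, from the compounds shown here alone, is whether a saturated ring such as cyclohexyl or a nitrogen-containing ring such as pyridyl would keep the number reached with phenyl, and how a carboxylic acid on that phenyl would read. Among these compounds, for the allyl group only the step against hydrogen is known, so a propyl chain in its place remains an open comparison.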